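The source may hold more compounds than are shown below. What is called first, only, known or untested is meant among the compounds shown, and "the series" means these compounds.

Measured so far:
- compound 1, `CCCCNC(=O)N1CC1C#N`, 12000 nM in a functional assay on L1210 cells (Mus musculus) for inhibition, read by MTT assay; on this read-out higher numbers stand for weaker inhibition and lower numbers for stronger inhibition
- compound 2, `CC(C)(C)NC(=O)N1CC1C#N`, 132000 nM in this assay

Among the compounds with values here, compound 2 stands at the higher of the two numbers in this assay, and the only measured neighbour, compound 1, sits at a lower number. Within the data shown here, the one step on record, an 11-fold higher number from compound 1 to compound 2 (1.04 log units; beyond the scatter), shows that swapping butyl for tert-butyl on the amide-type nitrogen of the shared urea moves the number a long way toward weaker inhibition.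

Compound 3, `N#CC1CN1C(N)=O`, is not yet measured. It differs from compound 2 by hydrogen in place of tert-butyl on an amide-type nitrogen, so that the amide-type nitrogen carries no carbon substituent at all. Among the measured compounds shown here, the only step that bears on this change removed a chain in favour of a branched group; no measured step removes the group entirely. The expectation is therefore loose: shrinking the group is expected to move the number back down, but probably not past where compound 1 stands, giving a 3.8-fold lower number from compound 2 to compound 3 (0.58 log units; beyond the scatter) as the estimated step. Compound 3 is thus estimated at 35000 nM in this assay, with a plausible range from 8000 nM to 150000 nM.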

Compound 3, half-maximal inhibitory concentration: > 90000 nM
Compound 3 was reported as a limit; the forecaster's own chance of this, stated with the estimate: 15%; middle value at least 2.5-fold (0.41 log units) away from the limit.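

Compound 3 is reported only as a limit of the assay, not as a number: the limit of > 90000 nM in this assay, at which 1 of the 3 values shown sits.

From the compounds shown here alone, the step from compound 2 to compound 3 cannot be read through that limit, so it remains unknown whether hydrogen in place of tert-butyl moves the number up or down, or leaves it where it is. The comparison with the straight chain can be read, however: hydrogen in place of butyl on the amide-type nitrogen gives an at least 7.5-fold higher number from compound 1 to compound 3 (0.87 log units; beyond the scatter) in this assay, so making the group smaller does not by itself recover the stronger inhibition of compound 1, and among these three compounds only the butyl compound has a number clearly lower than the others.

Going by these compounds, what remains open is how the number changes between hydrogen and butyl, which a methyl, ethyl or propyl group on the same nitrogen could show. It is also unclear whether a longer chain such as hexyl, or a ring such as phenyl, would take the number lower than compound 1 does.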